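Anilide para substituent in a biaryl amide series

A few compounds are considered here, and "the series" means these few. Any claim that something is new, unique, unknown or untested is made for them only; others in the source may bear on it.

Compound 1 `O=C(Nc1ccccc1)c1ccc(-c2ncccc2C(F)(F)F)cc1`: in a functional assay for antagonist activity at transient receptor potential cation channel subfamily V member 1 (Homo sapiens), read by FLIPR (on this read-out lower numbers stand for stronger inhibition and higher numbers for weaker inhibition), compound 1 gives > 4000 nM, a limit of the assay.
Compound 2 `N#Cc1ccc(NC(=O)c2ccc(-c3ncccc3C(F)(F)F)cc2)cc1`: in this assay compound 2 gives 417 nM.
Compound 3 `Cc1cccnc1-c1ccc(C(=O)Nc2ccc(F)cc2)cc1`: in this assay compound 3 gives > 4000 nM, again a limit.
Compound 4 `Cc1cccnc1-c1ccc(C(=O)Nc2ccc(C(C)(C)C)cc2)cc1`: not yet measured in this assay.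

Compound 3 therefore stands only at the limit of > 4000 nM in this assay, at which 2 of the 3 values shown sit; no number is known for it. Compound 4 differs from it by tert-butyl in place of fluoro on an aromatic carbon. Among the measured compounds shown here, the single measured step, an at least 9.5-fold lower number from compound 1 to compound 2 (0.98 log units; beyond the scatter), concerns a different group at a comparable place and shows that a change there can move the number well beyond the scatter; no measured step involves a tert-butyl or a fluoro. On this basis a move to a lower number is expected for compound 4, an at least 3.3-fold lower number from compound 3 to compound 4 (0.52 log units; beyond the scatter), with wide uncertainty. Compound 4 is estimated at 1200 nM, ranging from 150 nM to 6000 nM.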

Compound 4, half-maximal inhibitory concentration: 11 nM
Compound 4: middle estimate off by 110-fold (2.04 log units), on the high side; the measured number lies below the stated range.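

Among the compounds shown here, changing fluoro to tert-butyl on the anilide ring gives an at least 360-fold lower number from compound 3 to compound 4 (2.56 log units; beyond the scatter) in this assay, so this position can carry far stronger inhibition than the earlier compounds showed. The tert-butyl group carries no hydrogen-bond donor or acceptor, and compound 4 still reaches 11 nM. The value of compound 3 is a limit, and the step is therefore only a bound: the limit of > 4000 nM in this assay, at which 2 of the 4 values shown sit.

Still open, from the compounds shown here alone, is how a linear butyl chain, an isopropyl group or an amine would compare at this position. Going by these compounds, the effect of tert-butyl on the core of compound 1 also remains open.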